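Fluorophenyl Amide Expected from Three Weak Analogues

The compounds below may be only part of what the source reports. "The series", "measured", "known", "first", "only" and "open" are said of these compounds alone.

Measured in a functional assay on P388 cells (Mus musculus) for inhibition, read by MTT assay, with a stated time of 72 h; on this read-out higher numbers stand for weaker inhibition and lower numbers for stronger inhibition:
compound 1 `O=C(Nc1ccccc1)c1ccc(/N=N\c2c[nH]c3ccccc23)cc1` gives "not active" (no number reported)
compound 2 `Cc1ccc(NC(=O)c2ccc(/N=N\c3c[nH]c4ccccc34)cc2)c(C)c1` gives 190000 nM
compound 3 `O=C(Nc1cccc(Cl)c1)c1ccc(/N=N\c2c[nH]c3ccccc23)cc1` gives 267000 nM

Compound 3 carries the higher of the two reported numbers, with compound 2 nearest, and the step between them, a 1.4-fold higher number from compound 2 to compound 3 (0.15 log units; within the scatter), stays within the scatter. Compound 1 returns no number at all. Compound 4 `O=C(Nc1ccccc1F)c1ccc(/N=N\c2c[nH]c3ccccc23)cc1` differs from compound 3 by 2-fluorophenyl in place of 3-chlorophenyl on an amide-type nitrogen. Among the compounds with values here, only one measured step concerns this position, a 1.4-fold higher number from compound 2 to compound 3 (0.15 log units; within the scatter), and it did not leave the scatter, so no shift beyond the scatter is expected in this assay. Compound 1 shows "not active" (no number reported), so compound 4 may likewise yield no number. Compound 4 is therefore estimated at 300000 nM, within 120000 nM to 800000 nM, an expected step of a 1.1-fold higher number from compound 3 to compound 4 (0.05 log units; within the scatter).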

Compound 4, half-maximal inhibitory concentration: 106000 nM
Compound 4: the middle estimate sits 2.8-fold (0.45 log units) above what was measured; measured number outside the range, below it.
By their numbers in this assay, from the lowest: compounds 4, 2 and 3 (each within the scatter of the next, the first and the last beyond it).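

In this assay the group on the amide-type nitrogen can move the number beyond the scatter, as 2-fluorophenyl in place of 3-chlorophenyl shows (a 2.5-fold lower number from compound 3 to compound 4 (0.40 log units; beyond the scatter)). The earlier step at this position did not show this. Against 2,4-dimethylphenyl, however, 2-fluorophenyl stays within the scatter (a 1.8-fold lower number from compound 2 to compound 4 (0.25 log units; within the scatter)), so the shift holds for only one of the two comparisons, and nothing available accounts for it.

On these data alone, whether an amine or a carboxylic acid on this phenyl ring would shift the number further remains open.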